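The compounds below may be only part of what the source reports. "The series", "measured", "known", "first", "only" and "open" are said of these compounds alone.

Measured compounds:
- compound 1 `CN1CCN(CCCOc2cccc3nc(Nc4ccc(Cl)c(C(F)(F)F)c4)ccc23)CC1` — in a functional assay on cells (Panel breast (Carcinoma cell lines), Homo sapiens) for inhibition, read by sulforhodamine B assay, with a stated time of 48 h (on this read-out higher numbers stand for weaker inhibition of growth and lower numbers for stronger inhibition of growth), compound 1 gives 3630 nM
- compound 2 `CN1CCN(CCCOc2cccc3nc(Nc4ccc(Cl)c(F)c4)ccc23)CC1` — compound 2 gives 4500 nM
- compound 3 `CN1CCN(CCCOc2cccc3nc(Nc4ccc(F)c(F)c4)ccc23)CC1` — compound 3 gives 7980 nM

Compound 3 has the highest number of the three, though its gap to compound 2 falls within the scatter. Compound 4 `CN1CCN(CCCOc2cccc3nc(Nc4cc(Cl)cc(Cl)c4)ccc23)CC1` differs from it by 3,5-dichlorophenyl in place of 3,4-difluorophenyl on a nitrogen on an aromatic ring. Going by the values given here, two measured steps bear on this swap of halogens: a 1.8-fold higher number from compound 2 to compound 3 (0.25 log units; within the scatter), and a 2.2-fold higher number from compound 1 to compound 3 (0.34 log units; beyond the scatter). Both point to a lower number when fluorine gives way to a larger halogen. Compound 4 is therefore expected to move in the same direction, a 2.0-fold lower number from compound 3 to compound 4 (0.30 log units; within the scatter), a modest step. The estimate for compound 4 in this assay is 4000 nM, with a range from 1800 nM to 9000 nM.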

Compound 4, concentration for total growth inhibition: 5670 nM
The estimate for compound 4 lay 1.4-fold (0.15 log units) below the measured number, and the stated range covers the measured number.
By their numbers in this assay, from the lowest: compounds 1, 2, 4 and 3 (each within the scatter of the next, the first and the last beyond it).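

In this assay, 3,5-dichlorophenyl on this nitrogen stays within the scatter of all three earlier groups: a 1.4-fold lower number from compound 3 to compound 4 (0.15 log units; within the scatter); a 1.3-fold higher number from compound 2 to compound 4 (0.10 log units; within the scatter); and a 1.6-fold higher number from compound 1 to compound 4 (0.19 log units; within the scatter). Compound 4 therefore cannot be separated from any of them, even though compound 1 and compound 3 lie beyond the scatter of each other. Nothing available explains this result. From the compounds shown here alone, what stays open is how a phenyl carrying a methoxy group or a nitrile in place of the halogens would read in this assay.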